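Amide Substituents and Writhing Inhibition in a Small Series

The compounds below may be only part of what the source reports. "The series", "measured", "known", "first", "only" and "open" are said of these compounds alone.

Measured compounds:
Compound 1, `COc1cc2c(cc1OC)C(CC(N)=O)CC2`: 24.6%
Compound 2, `CNC(=O)CC1CCc2cc(OC)c(OC)cc21`: 21.2%
Compound 3, `CCCNC(=O)CC1CCc2cc(OC)c(OC)cc21`: 26.9%

In a functional assay on the whole organism (strain Swiss albino) for inhibition, with Mus musculus as the target, in the writhing test, with stated times of 60 min and 15 min, at a dose of 100 mg/kg by the oral route (on this read-out higher numbers stand for more inhibition at the one dose given (going by the name of the read-out) and lower numbers for less inhibition), compound 3 carries the highest of the three numbers, yet its gaps to compound 1 and compound 2 both lie within the scatter, so no ranking can be drawn from them. Compound 4, `COc1cc2c(cc1OC)C(CC(=O)NC(C)(C)C)CC2`, differs from compound 3 in one place: tert-butyl in place of propyl on an amide-type nitrogen. Every measured step at this amide-type nitrogen bears on the change, and each was small: a number 3.4 percentage points lower from compound 1 to compound 2 (within the scatter), a number 2.3 percentage points higher from compound 1 to compound 3 (within the scatter) and a number 5.7 percentage points higher from compound 2 to compound 3 (within the scatter). Varying the group on this nitrogen has so far moved the read-out by nothing beyond the scatter. The step to compound 4 is therefore expected to be a number 1.9 percentage points lower from compound 3 to compound 4 (within the scatter), no more than scatter in either direction. Compound 4 is estimated at 25%, between 12% and 38%.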

Compound 4, a percentage reported as inhibition, in the whole organism at one dose (the size of the read-out at that dose, not a potency): 41.8%
Compound 4: middle estimate off by 16.8 percentage points, on the low side; the whole stated range lies below it.
By their numbers in this assay, from the lowest: compounds 2, 1 and 3 (each within the scatter of the next); then compound 4.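

Read in this assay the amide-type nitrogen is not indifferent to its group: tert-butyl gives a number 14.9 percentage points higher from compound 3 to compound 4 (beyond the scatter) and also a number 20.6 percentage points higher from compound 2 to compound 4 (beyond the scatter) as well as a number 17.2 percentage points higher from compound 1 to compound 4 (beyond the scatter). Hydrogen, methyl and propyl on this nitrogen remain within the scatter of one another, so among these compounds only tert-butyl separates from the rest. Nothing available accounts for this rise. Going by these compounds, whether isopropyl, cyclohexyl or a phenyl ring on this nitrogen would match tert-butyl remains open. So does whether the tert-butyl amide keeps its lead at other oral doses.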